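Replacing oxetan-3-yl with 2-methoxyethyl on the shared core

This account rests on a few compounds, and the source may have more. Where it says the series, first, only, none or still open, it means among the compounds named here.

Measured so far in a physicochemical assay for solubility, measured as kinetic solubility; on this read-out higher numbers stand for higher solubility and lower numbers for lower solubility:
Compound 1 `Cc1ccccc1N1C(=O)/C(=C/c2ccc(O)c(Cl)c2)S/C1=N\CCO`: > 250000 nM, a limit of the assay
Compound 2 `Cc1ccccc1N1C(=O)/C(=C/c2ccc(O)c(Cl)c2)S/C1=N\CCCF`: 20000 nM
Compound 3 `Cc1ccccc1N1C(=O)/C(=C/c2ccc(O)c(Cl)c2)S/C1=N\C1COC1`: 150000 nM

Among the compounds with values here, only two of these readings are true numbers, and the gap between them is a 7.5-fold higher number from compound 2 to compound 3 (0.88 log units; beyond the scatter). That makes compound 3 the higher of the two, while compound 1 offers only its limit for comparison.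

In compound 4 `COCC/N=C1\S/C(=C\c2ccc(O)c(Cl)c2)C(=O)N1c1ccccc1C`, 2-methoxyethyl stands in place of oxetan-3-yl on a double-bonded nitrogen: 2-methoxyethyl in place of oxetan-3-yl on a double-bonded nitrogen. Within the data shown here, no measured step makes this exact exchange. The closest are the two steps that end in oxetan-3-yl. One is an at least 1.6-fold lower number from compound 1 to compound 3 (0.22 log units; that floor lies within the scatter), and the other is the step already given, which lies beyond the scatter. The two open chains they start from are themselves far apart, with an at least 12-fold lower number from compound 1 to compound 2 (1.09 log units; beyond the scatter). Since 2-methoxyethyl is also an open chain, compound 4 is expected to fall within that wide span, with no firm reason to place it near either end. A small move to a lower number is therefore expected, close to the edge of the scatter, and the estimated change is a 1.9-fold lower number from compound 3 to compound 4 (0.27 log units; within the scatter). The estimate in this assay for compound 4 is 80000 nM, with an expected range of 25000 nM to 220000 nM.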

Compound 4, solubility: 110000 nM
The estimate for compound 4 lay 1.4-fold (0.14 log units) below the measured number; measured number inside the range.
By their numbers in this assay, from the lowest: compound 2; then compounds 4 and 3 (each within the scatter of the next). At a limit, above all of these: compound 1.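

In this assay, a 1.4-fold lower number from compound 3 to compound 4 (0.13 log units; within the scatter) shows that on a double-bonded nitrogen, 2-methoxyethyl and oxetan-3-yl cannot be told apart, although one group has no ring and the other a four-membered ring, with the same heavy-atom and acceptor counts. Having no ring therefore does not by itself settle the number at this position: methoxy in place of fluoromethyl gives a 5.5-fold higher number from compound 2 to compound 4 (0.74 log units; beyond the scatter), which places compound 4 with compound 3 and clearly apart from compound 2. Methyl in place of hydrogen on the chain oxygen gives an at least 2.2-fold lower number from compound 1 to compound 4 (0.35 log units; beyond the scatter), so even this small change at the end of the chain has a readable effect, but its full size stays unknown, as compound 1 reads only at a limit of the assay: the limit of > 250000 nM in this assay, at which 1 of the 4 values shown sits.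

The compounds shown leave open whether an amine or a carboxylic acid at the end of this chain, or a longer chain ending in methoxy, would stay with compound 3 and compound 4 or move away from them. All four compounds carry the shared core, so whether the exchange of oxetan-3-yl for 2-methoxyethyl would read the same way on another core remains untold.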